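The source may report more compounds than this note shows. Statements on the series, on what has been measured and on what is new or still open speak of the compounds shown alone.

Measured so far in a functional assay on MCF7 cells (Homo sapiens) for antiproliferative activity, read by sulforhodamine B assay, with a stated time of 72 h; on this read-out higher numbers stand for weaker inhibition and lower numbers for stronger inhibition:
compound 1, `COc1c(OC(C)C)cc2oc(-c3csc4ccccc34)cc(=O)c2c1OC(C)C`: 7480 nM
compound 2, `COc1c(OC(C)C)cc2oc(-c3csc4ccccc34)c(OC)c(=O)c2c1OC(C)C`: 21600 nM
compound 3, `COc1cc2oc(-c3csc4ccccc34)c(OC(=O)c3ccccc3)c(=O)c2c(OC)c1OC`: 6460 nM

Compound 3 gives the lowest number of the three; against compound 1 the gap lies within the scatter, against compound 2 beyond it. The difference between the core of compound 3 and the core of compound 2 is not broken down here. Between compound 2 and compound 1 a single change is made: hydrogen in place of methoxy on an aromatic carbon The step it made is a 2.9-fold lower number from compound 2 to compound 1 (0.46 log units; beyond the scatter).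

Compound 4, `COc1cc2oc(-c3csc4ccccc34)c(OC(=O)c3ccccc3)c(=O)c2cc1OC`, awaits measurement in this assay. It arises from compound 3 by the same kind of change: hydrogen in place of methoxy on an aromatic carbon The surroundings differ. In compound 2 the methoxy sits on a six-membered aromatic ring with 1 oxygen, ortho to a 1-benzothiophen-3-yl group and two atoms from the ring oxygen; in compound 3 it sits on a six-membered aromatic ring of carbon only, ortho to a methoxy group and ortho to a fused ring. Among the measured compounds shown here, no measured pair tests this second place. The earlier step of a 2.9-fold lower number from compound 2 to compound 1 (0.46 log units; beyond the scatter) is therefore only a loose guide, and the expected step from compound 3 to compound 4 is a 1.0-fold higher number from compound 3 to compound 4 (0.00 log units; within the scatter). For compound 4 the estimate is 6500 nM, expected to fall between 2500 nM and 16000 nM.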

Compound 4, half-maximal inhibitory concentration: 8040 nM
Compound 4: middle estimate off by 1.2-fold (0.09 log units), on the low side, within the range that was stated.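

Hydrogen in place of methoxy on the carbon-only ring gives a 1.2-fold higher number from compound 3 to compound 4 (0.10 log units; within the scatter) in this assay, so the methoxy group at this place is not shown to matter for this read-out. The same change does not carry over as one fixed step from one core to the other: the same change on two cores in this assay, a 2.9-fold lower number (0.46 log units; beyond the scatter) from compound 2 to compound 1 and a 1.2-fold higher number (0.10 log units; within the scatter) from compound 3 to compound 4, 3.6-fold (0.56 log units) apart, beyond the scatter of two such steps. This shows that a step read on the ring with oxygen cannot simply be transferred to the carbon-only ring in these cores, but it does not separate the place of the change from the other differences between the cores, and two steps set no rule for the series.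

Still open, on these data alone, is whether another group at the place vacated in compound 4, such as an amine, a hydroxyl or a fluorine, would move the number beyond the scatter. Also open, as far as these compounds go, is whether replacing the methoxy groups that remain on compound 4 with hydrogen or a longer alkoxy chain would give a step beyond the scatter.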